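A few compounds are considered here, and "the series" means these few. Any claim that something is new, unique, unknown or untested is made for them only; others in the source may bear on it.

Measured in an ADME assay on HFF cells (Homo sapiens) for cytotoxicity, read by MTT assay, with a stated time of 72 h; a lower number here means a stronger inhibitor, a higher number a weaker inhibitor:
- compound 1 `COc1ccccc1-c1cn(C[C@H](O)[C@H]2OC(=O)C(OCc3ccccc3)=C2OCc2ccccc2)nn1`: 50 nM
- compound 2 `O=C1O[C@H]([C@@H](O)Cn2cc(CNS(=O)(=O)c3ccc(Cl)cc3)nn2)C(OCc2ccccc2)=C1OCc1ccccc1`: 20 nM
- compound 3 `O=C1O[C@H]([C@@H](O)Cn2cc(-c3cc(F)cc(F)c3)nn2)C(OCc2ccccc2)=C1OCc1ccccc1`: > 100000 nM, a limit of the assay and not a number

Compound 3 is known only through this limit: the limit of > 100000 nM in this assay, at which 1 of the 3 values shown sits.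

Compound 4 `O=C1O[C@H]([C@@H](O)Cn2cc(CCCCl)nn2)C(OCc2ccccc2)=C1OCc1ccccc1` differs from compound 3 at a single place, (3-chloropropyl in place of 3,5-difluorophenyl on an aromatic carbon), with 3-chloropropyl in place of 3,5-difluorophenyl on an aromatic carbon. Two measured steps changed this same place and ended at compound 3. They are an at least 2000-fold higher number from compound 1 to compound 3 (3.30 log units; beyond the scatter) and an at least 5000-fold higher number from compound 2 to compound 3 (3.69 log units; beyond the scatter), and both are large. The step of a 2.5-fold lower number from compound 1 to compound 2 (0.40 log units; beyond the scatter), at that place too, is only modest. Neither compound 1 nor compound 2 carries 3-chloropropyl, so these steps give a direction but only a loose size. A large move toward a lower number in this assay is expected, although compound 4 could also remain at the limit.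

For compound 4 the estimated value is 5000 nM, with an expected range from 100 nM to 100000 nM.

This estimate means an expected at least 20-fold lower number from compound 3 to compound 4 (1.30 log units; beyond the scatter).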

Compound 4, half-maximal inhibitory concentration: 27100 nM
For compound 4 the middle estimate is 5.4-fold (0.73 log units) below the measured one; the measured number falls inside the stated range.
By their numbers in this assay, from the lowest: compound 2; then compound 1; then compound 4. At a limit, above all of these: compound 3.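

In this assay, a group without a ring at this place on the five-membered aromatic ring brings the number off the limit, giving an at least 3.6-fold lower number from compound 3 to compound 4 (0.56 log units; beyond the scatter). Compound 3 is known only through a limit, so this step has a minimum size and no exact one: the limit of > 100000 nM in this assay, at which 1 of the 4 values shown sits. The chain does not reach the low numbers of the other two compounds, however, with a 1400-fold higher number from compound 2 to compound 4 (3.13 log units; beyond the scatter) and a 540-fold higher number from compound 1 to compound 4 (2.73 log units; beyond the scatter), so 3-chloropropyl lies between the extremes set by the ring-bearing groups of compound 1 and compound 3.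

The compounds shown leave open whether the chlorine or the chain itself accounts for this intermediate number. A plain propyl chain, a longer chloroalkyl chain or a 3-aminopropyl group at this place would begin to separate the two.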